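A few compounds are considered here, and "the series" means these few. Any claim that something is new, unique, unknown or untested is made for them only; others in the source may bear on it.

Measured in an ADME assay on L02 cells (Homo sapiens) for cytotoxicity, read by MTT assay, with a stated time of 48 h; on this read-out higher numbers stand for weaker inhibition and lower numbers for stronger inhibition:
- Compound 1 `CCn1c(C(=O)NCCCN(C)C)ccc1C(CC)(CC)c1ccc(OCC(=O)C(C)(C)C)c(C)c1`: 670 nM
- Compound 2 `CCN(CC)CCNC(=O)c1ccc(C(CC)(CC)c2ccc(OCC(O)C(C)(C)C)c(C)c2)n1CC`: 2500 nM
- Compound 3 `CCn1c(C(=O)NCCN(C)C)ccc1C(CC)(CC)c1ccc(OCC(O)C(C)(C)C)c(C)c1`: 2600 nM

Compound 3, at 2600 nM, sits level with compound 2 within the scatter, and both numbers lie clearly above that of compound 1. Compound 4 `CCn1c(C(=O)NCCCN(C)C)ccc1C(CC)(CC)c1ccc(OCC(O)C(C)(C)C)c(C)c1` has (dimethylamino)methyl in place of dimethylamino on a saturated chain carbon, two bonds along the chain from an amide-type nitrogen. This turns 2-(dimethylamino)ethyl into 3-(dimethylamino)propyl. Within the data shown here, the one measured step on this amine end, a 1.0-fold higher number from compound 2 to compound 3 (0.02 log units; within the scatter), stayed within the scatter. Compound 4 shares 3-(dimethylamino)propyl with compound 1, at 670 nM, but compound 1 also differs elsewhere, so it is only a weak guide. In this assay the expected change is a 1.2-fold lower number from compound 3 to compound 4 (0.07 log units; within the scatter), with no step beyond the scatter. The estimated value for compound 4 is 2200 nM, within an expected range of 1000 nM to 4800 nM.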

Compound 4, half-maximal inhibitory concentration: 470 nM
Compound 4: the middle estimate sits 4.7-fold (0.67 log units) above what was measured, and the stated range ends above it.
By their numbers in this assay, from the lowest: compounds 4 and 1 (each within the scatter of the next); then compounds 2 and 3 (each within the scatter of the next).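

In this assay, the longer 3-(dimethylamino)propyl chain makes a real difference (a 5.5-fold lower number from compound 3 to compound 4 (0.74 log units; beyond the scatter)), and the change from diethylamino on the shorter chain is of similar size (a 5.3-fold lower number from compound 2 to compound 4 (0.73 log units; beyond the scatter)), so this amine end responds to chain length, which the earlier step on its amine could not show. With 3-(dimethylamino)propyl in place, 1-hydroxy-2,2-dimethylpropyl instead of (tert-butyl)carbonyl stays within the scatter (a 1.4-fold lower number from compound 1 to compound 4 (0.15 log units; within the scatter)). Nothing measured here explains the chain-length effect.

Going by these compounds, whether 4-(dimethylamino)butyl would continue the trend remains open. So does the effect of 3-(diethylamino)propyl.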